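The compounds below may be only part of what the source reports. "The series", "measured", "known", "first", "only" and "open" are said of these compounds alone.

Of the compounds shown here, two have been measured in an assay on HEK293 cells for displacement of a labelled ligand from 5-hydroxytryptamine receptor 7 (Homo sapiens); a higher number here means a weaker inhibitor, a lower number a stronger inhibitor. Compound 1 `O=c1n(CCN2CCN(c3ccccc3)CC2)c2ccccc2n1-c1ccccc1` gives 1230 nM, and compound 2 `COc1ccc(-n2c(=O)n(CCCN3CCN(c4ccccc4OC)CC3)c3ccccc32)cc1` gives 168 nM. Compound 1 therefore stands at the highest number of the two, with compound 2 lying below it by a margin beyond the usual scatter; the two structures differ in several places at once, so their gap cannot be tied to any single change.

Compound 3 `Cc1ccccc1-n1c(=O)n(CCN2CCN(c3ccccc3)CC2)c2ccccc21`, not yet measured, differs from compound 1 in one place: methyl in place of hydrogen on an aromatic carbon.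

Among the compounds with values here, no measured pair here shows what a methyl on that aromatic carbon does, so the expectation rests only on the size of the change, which is small. For compound 3 a step of a 1.4-fold lower number from compound 1 to compound 3 (0.14 log units; within the scatter) is expected, not clearly beyond the scatter in either direction. Compound 3 is thus expected to give about 900 nM in this assay, with a range from 300 nM to 2700 nM.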

Compound 3, inhibition constant: 902 nM
For compound 3 the middle estimate is 1.0-fold (0.00 log units) below the measured one; measured number inside the range.
By their numbers in this assay, from the lowest: compound 2; then compounds 3 and 1 (each within the scatter of the next).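

Within the data shown here, this is the first change that can be read on its own: going from phenyl to 2-methylphenyl gives a 1.4-fold lower number from compound 1 to compound 3 (0.13 log units; within the scatter) in this assay. At this position, on an aromatic carbon ortho to a large group, a single methyl therefore leaves the binding number within the normal spread of repeat measurements. Nothing available gives a measured reason for this result.

As far as these compounds go, it remains open whether a larger or very different group at this position, such as an isopropyl or a carboxylic acid, would also leave the number within that spread, and whether a methyl elsewhere on the ring would do the same. Compound 2 differs from compound 1 in several places, so the contribution of each of those changes also remains unresolved.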